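Methylsulfanyl for dimethylamino on the shared core

The source may report more compounds than this note shows. Statements on the series, on what has been measured and on what is new or still open speak of the compounds shown alone.

Compound 1 `CN(C)c1nc(N)c2ncn([C@@H]3C[C@@H](O)[C@H](CO)O3)c2n1` carries a dimethylamino group on the shared core. In a functional assay on HL-60 cells (Homo sapiens) (a lower number here means a stronger inhibitor, a higher number a weaker inhibitor), compound 1 reaches only the limit of the assay, at > 300 uM, with no number below it; the limit of > 300 uM in this assay, at which 1 of the 2 values shown sits, marks that limit. Compound 2 `CNc1nc(Br)nc2c1ncn2[C@@H]1C[C@@H](O)[C@H](CO)O1` is the other measured member, and in this assay compound 2 gives 143 uM. Compound 3 `CSc1nc(N)c2ncn([C@@H]3C[C@@H](O)[C@H](CO)O3)c2n1` differs from compound 1 by one change: methylsulfanyl in place of dimethylamino on an aromatic carbon. Among the measured compounds shown here, no measured step covers this change, so no direction beyond the scatter is expected, and the step from compound 1 to compound 3 is estimated as an at least 1.2-fold lower number from compound 1 to compound 3 (0.07 log units; that floor lies within the scatter). Compound 3 is expected to give about 250 uM, within 70 uM to 800 uM.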

Compound 3, concentration for 50% inhibition: > 300 uM
Compound 3: only a limit was reported (the forecaster's own chance of this, stated with the estimate: 55%); middle value at least 1.2-fold (0.07 log units) away from the limit.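

Compound 1 and compound 3 both stop at the limit of the assay, so no step between them can be read: the limit of > 300 uM in this assay, at which 2 of the 3 values shown sit.

Going by these compounds, whether methylsulfanyl or dimethylamino on the shared core gives the lower number in this assay remains open.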